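The source may report more compounds than this note shows. Statements on the series, on what has been measured and on what is new or still open speak of the compounds shown alone.

Compound 3 `C=CCC1CC(=O)N(c2ccccc2C(=O)OCC2CCCN(CCCc3ccccc3)C2)C1=O` gives 1700 nM in a functional assay with Neuronal acetylcholine receptor; alpha3/beta4 (Homo sapiens) as the target; on this read-out lower numbers stand for stronger inhibition and higher numbers for weaker inhibition. On the numbers shown compound 3 sits at the low end: compound 2 `CC(C)C1CC(=O)N(c2ccccc2C(=O)OCC2CCCN(CCCc3ccccc3)C2)C1=O` gives 2500 nM, a gap within the scatter, and compound 1 `CCC1CC(=O)N(c2ccccc2C(=O)OCC2CCCN(CCCc3ccccc3)C2)C1=O` gives 4500 nM, a gap beyond it. Compound 4 `O=C(OCC1CCCN(CCCc2ccccc2)C1)c1ccccc1N1C(=O)CC(Cc2ccccc2)C1=O` is not yet measured; it differs from compound 3 by phenyl in place of vinyl on a saturated chain carbon bound to a saturated ring carbon. Among the measured compounds shown here, three measured steps concern the same place on the saturated chain carbon. a 2.6-fold lower number from compound 1 to compound 3 (0.42 log units; beyond the scatter) is the only one beyond the scatter, while a 1.8-fold lower number from compound 1 to compound 2 (0.26 log units; within the scatter) and a 1.5-fold lower number from compound 2 to compound 3 (0.17 log units; within the scatter) stay within it. So far each enlargement of the group at this place has either lowered the number or left it within the scatter, but no measured compound carries an aromatic ring there, so the move to phenyl rests on a thin base. A modest further decrease is expected, of the size a 1.7-fold lower number from compound 3 to compound 4 (0.23 log units; within the scatter). Compound 4 is estimated at 1000 nM, with a range from 300 nM to 3500 nM.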

Compound 4, half-maximal inhibitory concentration: 1300 nM
For compound 4 the middle estimate is 1.3-fold (0.11 log units) below the measured one; low and high end bracket the measured number.
By their numbers in this assay, from the lowest: compounds 4, 3, 2 and 1 (each within the scatter of the next, the first and the last beyond it).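

In this assay the first aromatic ring at this place, on a saturated chain carbon bound to a saturated ring carbon, leaves the read-out within the scatter of the smaller groups: a 1.3-fold lower number from compound 3 to compound 4 (0.12 log units; within the scatter) for phenyl in place of vinyl and a 1.9-fold lower number from compound 2 to compound 4 (0.28 log units; within the scatter) for benzyl in place of isopropyl. Only the comparison with the smallest group in the set, a 3.5-fold lower number from compound 1 to compound 4 (0.54 log units; beyond the scatter) for phenyl in place of methyl, goes beyond the scatter, and that step remains modest. Nothing available bears on what lies behind these steps.

All groups shown at this place contain only carbon and hydrogen, so the effect of an amine, a hydroxyl or a carboxylic acid there remains open. Also open, going by these compounds, is whether a longer chain such as 2-phenylethyl, or a substituted benzyl, would move the number beyond the scatter of compound 4.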